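Replacing a Bromophenyl Amide with a tert-Butyl Isoxazole Amide

This account rests on a few compounds, and the source may have more. Where it says the series, first, only, none or still open, it means among the compounds named here.

Measured compounds in an assay on isolated protein for inhibition of Rho-associated protein kinase 1 (Homo sapiens), read by scintillation counting, radiometric assay and 33P incorporation, with a stated time of 40 min, in the presence of a further agent that is not named here; on this read-out lower numbers stand for stronger inhibition and higher numbers for weaker inhibition:
Compound 1, `COc1cccc(OCC(=O)Nc2cccc(NC(=O)c3ccc(N(C)C)cc3)c2)c1`, gives only the limit > 10000 nM.
Compound 2, `CN(C)c1ccc(C(=O)Nc2cccc(NC(=O)COc3ccc4occc(=O)c4c3)c2)cc1`, also gives only the limit > 10000 nM.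
Compound 3, `O=C(COc1ccc2c(=O)ccoc2c1)Nc1cccc(NC(=O)c2ccc(Br)cc2)c1`, gives 303 nM.

For the measured compounds named here, compound 3 is thus the only compound with a measured number; the other two sit at the limit of > 10000 nM in this assay, at which 2 of the 3 values shown sit. The step that the two limits leave unreadable from compound 1 to compound 2 stays unreadable because the limit of > 10000 nM in this assay, at which 2 of the 3 values shown sit, covers both of its ends.

Compound 4, `CC(C)(C)c1cc(C(=O)Nc2cccc(NC(=O)COc3ccc4c(=O)ccoc4c3)c2)no1`, is not yet measured. It differs from compound 3 by 5-(tert-butyl)-1,2-oxazol-3-yl in place of 4-bromophenyl on a carbonyl carbon. Going by the values given here, no measured step touches this part of the molecule, so no direction is expected; the estimate rests on compound 3 alone with wide bounds. Compound 4 is expected to give about 500 nM, between 120 nM and 3000 nM, an expected step of a 1.7-fold higher number from compound 3 to compound 4 (0.22 log units; within the scatter) within the scatter.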

Compound 4, half-maximal inhibitory concentration: 101 nM
Compound 4: middle estimate off by 5.0-fold (0.69 log units), on the high side; measured number below the stated range.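

In this assay, the group on this carbonyl carbon can be exchanged without losing inhibition: 5-(tert-butyl)-1,2-oxazol-3-yl in place of 4-bromophenyl brings a 3.0-fold lower number from compound 3 to compound 4 (0.48 log units; beyond the scatter). For the compounds shown here, this is the first readable step at this place, and it shows that neither the carbon-only ring nor the bromine is needed for inhibition in these two compounds. Nothing measured here explains the change. Still open, from the compounds shown here alone, is which part of the new group carries the gain, the tert-butyl or the ring itself. A 5-methyl-1,2-oxazol-3-yl group or an added amine at this place could give a different result.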